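Ring Swap on Compound 2: What the Numbers Suggest

The source may hold more compounds than are shown below. What is called first, only, known or untested is meant among the compounds shown, and "the series" means these compounds.

Three compounds have been measured in a functional assay on SGC-7901 cells (Homo sapiens) for cytotoxicity, read by MTT assay, with a stated time of 72 h; a lower number here means a stronger inhibitor, a higher number a weaker inhibitor:
Compound 1, `O=C(Nc1ccc(-n2ncc3c(C(F)(F)F)cccc32)cc1)Nc1ccc(Cl)c(C(F)(F)F)c1`, gives only a limit of the assay, > 32000 nM.
Compound 2, `O=C(Nc1ccc(-n2ncc3c(F)cccc32)cc1)Nc1ccc(Cl)c(C(F)(F)F)c1`, gives 32000 nM.
Compound 3, `COc1cccc2c1cnn2-c1ccc(NC(=O)Nc2ccc(Cl)c(C(F)(F)F)c2)cc1`, gives 29800 nM.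

Compound 2 holds the highest of the two real numbers, but its gap to compound 3 is only a 1.1-fold lower number from compound 2 to compound 3 (0.03 log units; within the scatter). The value of compound 1 is a limit (the limit of > 32000 nM in this assay, at which 1 of the 3 values shown sits). Compound 4, `O=C(Nc1ccc(-n2ncc3cnccc32)cc1)Nc1ccc(Cl)c(C(F)(F)F)c1`, differs from compound 2 by a group of 9 heavy atoms (6 carbon, 3 nitrogen; one five-membered aromatic ring with 2 hetero atoms, one six-membered aromatic ring with 1 hetero atom) in place of a group of 10 heavy atoms (7 carbon, 2 nitrogen, 1 fluorine; one five-membered aromatic ring with 2 hetero atoms, one six-membered aromatic ring of carbon only), on an aromatic carbon. The earlier changes at that same group moved the numbers by a number no higher from compound 1 to compound 2 (the limit leaves the size open) and an at least 1.0-fold lower number from compound 1 to compound 3 (0.03 log units; that floor lies within the scatter), none beyond the scatter. The step of a 1.1-fold lower number from compound 2 to compound 4 (0.03 log units; within the scatter) is therefore expected to stay within the scatter as well. Compound 4 is estimated at 30000 nM, within 14000 nM to 64000 nM.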

Compound 4, half-maximal inhibitory concentration: 22600 nM
For compound 4 the middle estimate is 1.3-fold (0.12 log units) above the measured one; the range from low to high includes it.
By their numbers in this assay, from the lowest: compounds 4, 3 and 2 (each within the scatter of the next).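

In this assay, for the compounds shown here, the earlier steps exchanged only a group on the carbon-only six-membered ring, whereas this one puts a hetero atom into that ring itself. The outcome, a 1.4-fold lower number from compound 2 to compound 4 (0.15 log units; within the scatter), shows that even a change to the ring does not take the number outside the scatter in these compounds. Compound 1 remains a limit and not a number: the limit of > 32000 nM in this assay, at which 1 of the 4 values shown sits.

As far as these compounds go, whether an amine or a carboxylic acid on this ring would give a number clearly beyond the scatter stays open.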